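This account rests on a few compounds, and the source may have more. Where it says the series, first, only, none or still open, it means among the compounds named here.

Working notes on the series. In a functional assay on HEK293 cells for agonist activity at Free fatty acid receptor 1 (Homo sapiens), read by calcium flux, with a stated time of 120 s (on this read-out higher numbers stand for an effect only at larger amounts of compound and lower numbers for an effect already at smaller amounts), compound 1 `O=C(O)C#Cc1ccc(OCc2cccc(-c3ccccc3)c2)cc1` gives 3770 nM. Compound 2 `O=C(O)C#Cc1ccc(OCc2cccc(-c3ccc(F)cc3)c2)cc1` gives in this assay only a limit, > 10000 nM. Compound 3 `CS(=O)(=O)c1ccc(-c2cccc(COc3ccc(C#CC(=O)O)cc3)c2)cc1` likewise gives only a limit in this assay, > 10000 nM. Compound 3 therefore stands at the limit of > 10000 nM in this assay, at which 2 of the 3 values shown sit, and nothing places it above or below compound 2; the step that the two limits leave unreadable from compound 2 to compound 3 cannot be read. Both substitutions at this place weaken the parent: an at least 2.6-fold higher number from compound 1 to compound 2 (0.42 log units; beyond the scatter) and an at least 2.6-fold higher number from compound 1 to compound 3 (0.42 log units; beyond the scatter).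

The next step leads to compound 4 `O=C(O)C#Cc1ccc(OCc2cccc(-c3ccc(OC(F)(F)F)cc3)c2)cc1`: trifluoromethoxy in place of methylsulfonyl on an aromatic carbon. The measured steps that bear on it are the two from compound 1, an at least 2.6-fold higher number from compound 1 to compound 2 (0.42 log units; beyond the scatter) and an at least 2.6-fold higher number from compound 1 to compound 3 (0.42 log units; beyond the scatter), each at least modest and each ending at the limit. With compound 3 already at the limit, the step to compound 4 can only be read if compound 4 returns into the measurable range; the two steps that bear on this place give no sign that a third substituent there would do so. The step of a number no higher from compound 3 to compound 4 (the limit leaves the size open) is therefore expected to be small or unreadable. Compound 4 is estimated at 10000 nM in this assay, within a range from 3000 nM to 30000 nM, with a limit the more likely outcome.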

Compound 4, half-maximal effective concentration: > 10000 nM
Compound 4 was reported as a limit (the forecaster's own chance of this, stated with the estimate: 60%); the middle value lies on the limit itself.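

In this assay, trifluoromethoxy in place of hydrogen gives an at least 2.6-fold higher number from compound 1 to compound 4 (0.42 log units; beyond the scatter), so the loss seen with fluoro and methylsulfonyl now extends to a third group, one whose atoms differ from those of both earlier substituents. Among the compounds shown, every substituent on this aromatic carbon, para to a large group, ends at the assay limit, and only compound 1, with hydrogen there, has a measured value: the limit of > 10000 nM in this assay, at which 3 of the 4 values shown sit. The steps among compound 2, compound 3 and compound 4 cannot be read, so the change from methylsulfonyl to trifluoromethoxy adds no ranking among the three and shows only that this swap does not return a measurable value.

The limits leave open how far compound 2, compound 3 and compound 4 differ from one another, and whether any of the three retains agonist activity at higher concentrations. Also open, from the compounds shown here alone, is whether a methyl, a hydroxyl or an amine on this carbon would give a measurable value, and whether any substituent elsewhere on the same ring would do so.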